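Taking the nitro group off compound 2

The source may report more compounds than this note shows. Statements on the series, on what has been measured and on what is new or still open speak of the compounds shown alone.

In a functional assay on cells (Homo sapiens) for inhibition, read by MTT assay, with a stated time of 72 h (on this read-out higher numbers stand for weaker inhibition and lower numbers for stronger inhibition), compound 2 (`O=C(O)Cn1ncc2c(Nc3ccc(NS(=O)(=O)c4ccc([N+](=O)[O-])cc4)cc3)ncnc21`) reads > 100 ug/mL and this is a limit, not a number. Compound 1 (`CCOC(=O)Cn1ncc2c(Nc3ccc(NS(=O)(=O)c4ccc([N+](=O)[O-])cc4)cc3)ncnc21`) gives > 64 ug/mL which is also a limit. Compound 3 (`CCOC(=O)Cn1ncc2c(Nc3ccc(N)cc3)ncnc21`) gives > 64 ug/mL and that too is a limit. No value shown in this assay is therefore a true number: the limit of > 100 ug/mL in this assay, at which 1 of the 3 values shown sits, and the limit of > 64 ug/mL in this assay, at which 2 of the 3 values shown sit, are the only two levels on record.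

Compound 4 (`O=C(O)Cn1ncc2c(Nc3ccc(NS(=O)(=O)c4ccccc4)cc3)ncnc21`) differs from compound 2 at one place, with hydrogen in place of nitro on an aromatic carbon is the whole change, and 4-nitrophenyl becomes phenyl. For the measured compounds named here, the one measured step is a step that the two limits leave unreadable from compound 1 to compound 2 and it concerns the ethyl group, not the nitro group, so it offers no size to carry over. Going by the values given here, with no measured step to suggest otherwise, no shift beyond the scatter is expected in this assay and the expected step is a number no higher from compound 2 to compound 4 (the limit leaves the size open) in no particular direction. The estimate for compound 4 is 100 ug/mL with an expected range from 50 ug/mL to 200 ug/mL and most likely only a limit will be reported.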

Compound 4, half-maximal inhibitory concentration: > 100 ug/mL
Compound 4: only a limit was reported (the forecaster's own chance of this, stated with the estimate: 85%); the middle value sits exactly at the limit.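

In this assay, compound 2 and compound 4 are both reported only as limits, and no size can be read for the step between them, the change from 4-nitrophenyl to phenyl. The compounds shown leave open whether removing the nitro group changes inhibition in this assay at all.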